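Isopropylcarbonyl to propanoyl: one small change

The source may report more compounds than this note shows. Statements on the series, on what has been measured and on what is new or still open speak of the compounds shown alone.

- compound 1 `COc1cc(/C=C2\CN(C)C/C(=C\c3cc(OC)c(OC)c(OC)c3)C2=O)cc(OC)c1OC` gives 1000 nM
- compound 2 `COc1cc(/C=C2\CN(C(=O)C(C)C)C/C(=C\c3cc(OC)c(OC)c(OC)c3)C2=O)cc(OC)c1OC` gives 2000 nM

Among the measured compounds shown here, both compounds were tested in a functional assay on NCI-H460 cells (Homo sapiens) for cytotoxicity, read by MTT assay, with a stated time of 72 h (a lower number here means a stronger inhibitor, a higher number a weaker inhibitor), and the two numbers cannot be told apart: the only measured step (a 2.0-fold higher number from compound 1 to compound 2 (0.30 log units; within the scatter)) stays within the scatter. Compound 2 therefore stands level with compound 1 on the evidence so far.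

Compound 3 `CCC(=O)N1C/C(=C\c2cc(OC)c(OC)c(OC)c2)C(=O)/C(=C/c2cc(OC)c(OC)c(OC)c2)C1` alters one detail of compound 2 (hydrogen in place of methyl on a saturated chain carbon bound to a carbonyl carbon and a saturated chain carbon). It carries hydrogen in place of methyl on a saturated chain carbon bound to a carbonyl carbon and a saturated chain carbon, so isopropylcarbonyl becomes propanoyl.

For the measured compounds named here, the measured step put isopropylcarbonyl in place of methyl on an amine nitrogen in a ring, and it is the only guide available. With so little data, no step beyond the scatter is expected in this assay. The estimated step (a 1.3-fold lower number from compound 2 to compound 3 (0.12 log units; within the scatter)) is accordingly small. For compound 3 the expected value is 1500 nM (estimated range 700 nM to 3500 nM).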

Compound 3, half-maximal inhibitory concentration: 2700 nM
Estimate against measurement, compound 3: 1.8-fold (0.26 log units) below; low and high end bracket the measured number.
By their numbers in this assay, from the lowest: compounds 1, 2 and 3 (each within the scatter of the next, the first and the last beyond it).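

Removing one methyl from the saturated chain carbon, so that isopropylcarbonyl becomes propanoyl, gives a 1.4-fold higher number from compound 2 to compound 3 (0.13 log units; within the scatter) in this assay, so this trimming of the acyl group has no effect that can be read. Set against the methyl on the amine nitrogen in a ring, however, propanoyl gives a 2.7-fold higher number from compound 1 to compound 3 (0.43 log units; beyond the scatter), the first modest step beyond the scatter here, although isopropylcarbonyl in compound 2 goes against any general rule that an acyl group on this nitrogen weakens the compounds. Nothing available explains this difference.

Still open, from the compounds shown here alone, is how a hydrogen on that nitrogen, or an acetyl group, would compare in this assay. A longer chain such as butanoyl, or a benzoyl group, would show whether the acyl group can go further without a larger step.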